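A Dimethoxyphenyl Swap on the Ring Nitrogen

The source may report more compounds than this note shows. Statements on the series, on what has been measured and on what is new or still open speak of the compounds shown alone.

Of the compounds shown here, three sharing one five-membered ring core have been tested in a functional assay on U2OS cells (Homo sapiens) for inhibition, read by CCK-8 assay, with a stated time of 72 h, tested at 1 uM; a lower number here means less inhibition, a higher number more inhibition at the concentration tested (going by the name of the read-out). Compound 1 `COc1ccccc1N1C(=O)CSC1C(=O)NCCCCc1ccccc1` gives 6%. Compound 2 `Cc1cccc(N2C(=O)CSC2c2cccc(C(=O)NCCCCc3ccccc3)c2)c1` gives 39%, the highest of the three numbers. Compound 3 `CCOc1ccccc1N1C(=O)C(C)SC1c1cccc(C(=O)NCCCCc2ccccc2)c1` gives 37%, which lies within the scatter of compound 2, so no order between those two can be read, while compound 1 sits well below both. Compound 4 `COc1ccc(N2C(=O)CSC2c2cccc(C(=O)NCCCCc3ccccc3)c2)c(OC)c1` is not yet measured. It differs from compound 2 in one place: 2,4-dimethoxyphenyl in place of 3-methylphenyl on an amide-type nitrogen in a ring. Within the data shown here, no measured pair shows this change, so its effect is unknown; a modest drop in this assay is expected, with little confidence in direction. The estimate for compound 4 is 28%, between 8% and 50%. The expected step is a number 11 percentage points lower from compound 2 to compound 4 (beyond the scatter).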

Compound 4, a percentage reported as inhibition, at one concentration (the size of the read-out at that concentration, not a potency): 37%
For compound 4 the middle estimate is 9 percentage points below the measured one, and the stated range covers the measured number.
By their numbers in this assay, from the lowest: compound 1; then compounds 3, 4 and 2 (each within the scatter of the next).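

In this assay, placing 2,4-dimethoxyphenyl in place of 3-methylphenyl on the amide-type nitrogen in a ring gives a number 2 percentage points lower from compound 2 to compound 4 (within the scatter). Among these compounds, this is the first direct comparison at this position, and it shows that the swap to a group with more heavy atoms and two methoxy groups leaves the read-out unchanged at the concentration tested. No evidence here gives a reason for this result. Still open, going by these compounds, is whether an aminophenyl or carboxyphenyl group, or a plain butyl chain in place of the aromatic ring, would be accepted at this nitrogen equally well.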